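Bromo in Place of a Dicyanovinyl Group on a Shared Core

A few compounds are considered here, and "the series" means these few. Any claim that something is new, unique, unknown or untested is made for them only; others in the source may bear on it.

Measured so far:
Compound 1, `CC1(C)C=C(n2ccccc2=O)c2cc(C(=O)c3ccccc3F)ccc2O1`: 6.34
Compound 2, `CC1(C)C=C(n2ccccc2=O)c2cc(C=C(C#N)C#N)ccc2O1`: 6.3

Both compounds share one core and differ only in the group on an aromatic carbon. In a functional assay (trachea) with Rattus norvegicus as the target (a higher number here means a more potent compound, by a factor of ten per unit of this negative logarithm, a lower number a less potent compound), compound 1 gives 6.34, and compound 2 gives 6.3. Among the compounds with values here, the one step known, a number 0.04 log units lower from compound 1 to compound 2 (within the scatter), shows two quite different groups at that carbon giving the same result. Compound 2 stands as one of two numbers that sit within the scatter of each other, so neither can be called the stronger.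

Compound 3, `CC1(C)C=C(n2ccccc2=O)c2cc(Br)ccc2O1`, is not yet measured. It differs from compound 2 as follows: bromo in place of 2,2-dicyanoethenyl on an aromatic carbon. Within the data shown here, no measured step tells what a group as small as bromo does at this carbon; the single step only shows that the carbon tolerates two larger groups equally. The step of a number 0.30 log units lower from compound 2 to compound 3 (within the scatter) is therefore expected to be small, with wide uncertainty. Compound 3 is estimated to give 6, between 5.3 and 6.7.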

Compound 3, logarithm of the reciprocal of the active concentration, log(1/C): 7.53
Beside the measured number, compound 3's estimate is 1.53 log units below it; measured number outside the range, above it.
By their numbers in this assay, from the lowest: compounds 2 and 1 (each within the scatter of the next); then compound 3.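

In this assay bromo gives a number 1.23 log units higher from compound 2 to compound 3 (beyond the scatter) and a number 1.19 log units higher from compound 1 to compound 3 (beyond the scatter) on the shared core, so this aromatic carbon is not indifferent to the group it carries. The earlier match between 2,2-dicyanoethenyl and (2-fluorophenyl)carbonyl had suggested that the choice of group made little difference, yet bromo, a single atom, gives a clearly higher number than either larger group. No measurement available here explains this gain.

With only three groups shown at this carbon, it remains open whether the higher number belongs to bromo alone or extends to other groups. Chloro, methyl or an amine at the same carbon on the shared core would help to separate these possibilities.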